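Swapping the Sulfur-Bearing Ring for a Carbon Ring

A few compounds are considered here, and "the series" means these few. Any claim that something is new, unique, unknown or untested is made for them only; others in the source may bear on it.

This series shares one core and differs only in the five-membered ring hanging from the fluorinated benzene. Compound 1 `CCc1cnc(N2CCC(c3nc(COc4ccc(/C=C5\SC(=S)NC5=O)cc4F)cs3)CC2)nc1` carries a ring with two sulfur atoms, and in a functional assay on cells for agonist activity at Glucose-dependent insulinotropic receptor (Homo sapiens), read by a luciferase reporter, with a stated time of 6 h (on this read-out lower numbers stand for an effect already at smaller amounts and higher numbers for an effect only at larger amounts of compound), the entry for compound 1 reads "not determined" (no result reported). Compound 2 `CCc1cnc(N2CCC(c3nc(COc4ccc(/C=C5\SC(=O)NC5=O)cc4F)cs3)CC2)nc1` carries a ring with one sulfur and two carbonyls, and in this assay compound 2 gives 780 nM. Compound 3 `CCc1cnc(N2CCC(c3nc(COc4ccc(/C=C5\SC(=S)N(N)C5=O)cc4F)cs3)CC2)nc1` adds an amino group to the ring nitrogen of compound 1; in this assay the entry for compound 3 reads "not determined" (no result reported), so, as with compound 1, no number is available and compound 3 cannot be placed relative to compound 2 on the numbers shown.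

Compound 4 `CCc1cnc(N2CCC(c3nc(COc4ccc(/C=C5\CC(=O)NC5=O)cc4F)cs3)CC2)nc1` is made from compound 3 by the change (a group of 8 heavy atoms (5 carbon, 1 nitrogen, 2 oxygen; one five-membered non-aromatic ring with 1 hetero atom) in place of a group of 9 heavy atoms (4 carbon, 2 nitrogen, 1 oxygen, 2 sulfur; one five-membered non-aromatic ring with 2 hetero atoms), on an aromatic carbon). For the measured compounds named here, since compound 3 has no measured value, no size or direction of step can be given for this change in this assay; the only anchor is compound 2.

On that anchor, compound 4 is expected to land near 1500 nM, within a range of 400 nM to 6000 nM, resting on the value of compound 2 at 780 nM with the uncertainty widened for the untested ring.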

Compound 4, half-maximal effective concentration: 49 nM
For compound 4 the middle estimate is 31-fold (1.49 log units) above the measured one; the whole stated range lies above it.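

In this assay, exchanging the ring sulfur for a ring carbon gives a 16-fold lower number from compound 2 to compound 4 (1.20 log units; beyond the scatter), a large step and well beyond the usual scatter. For the compounds shown here, this is the first readable comparison at this position, and it shows that the ring hanging from the fluorinated benzene strongly affects the result: even one atom exchanged within it, with the two carbonyls and the ring nitrogen left in place, shifts the effect to much smaller amounts of compound. For this pair, therefore, the sulfur in the ring is not required for agonist activity, although nothing measured here explains the size of the step.

As far as these compounds go, with no numbers for compound 1 and compound 3, the effects of the ring's sulfur-bearing carbon and of the amino group on the ring nitrogen remain unknown, so this single pair cannot be extended into a rule. From the compounds shown here alone, it also remains open whether the gain would hold with an oxygen atom in place of the new ring carbon, with a methyl group attached to that carbon, or with a carboxylic acid in place of the whole ring.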